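The source may report more compounds than this note shows. Statements on the series, on what has been measured and on what is new or still open speak of the compounds shown alone.

Compound 1 `O=S(=O)(Nc1ccc2oc(-c3ccccc3)nc2c1)c1cccc(F)c1` is a sulfonamide built on a shared core; in an assay on isolated protein for inhibition of malate dehydrogenase, mitochondrial (Sus scrofa), with stated times of 45 min and 30 min (on this read-out higher numbers stand for weaker inhibition and lower numbers for stronger inhibition), compound 1 gives > 63000 nM, which is a limit of the assay rather than a number. Two further compounds were examined in the same way. Compound 2 `O=S(=O)(Nc1ccc(-c2nc3ccccc3o2)cc1)c1cccc(O)c1` also gives a limit, > 63000 nM, in this assay. Compound 3 `O=S(=O)(Nc1ccc2oc(-c3ccccc3)nc2c1)c1ccc(F)c(C(F)(F)F)c1` likewise gives a limit, > 63000 nM. So compound 1 stands where every value shown stands, namely at the limit of > 63000 nM in this assay, at which 3 of the 3 values shown sit, and no ranking among the three is possible.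

Compound 4 `O=S(=O)(Nc1ccc2oc(-c3ccccc3)nc2c1)c1cccs1` has not yet been measured. It differs from compound 1 in one place: thiophen-2-yl in place of 3-fluorophenyl on a sulfonyl sulfur. Within the data shown here, no change between two measured compounds resembles this one, so there is no measured step to lean on. Given that compound 1 sits at the limit of > 63000 nM in this assay, at which 3 of the 3 values shown sit, the expectation is that this change brings no step beyond the usual scatter, and that the assay most likely reports a limit once more. The estimate for compound 4 is 100000 nM, within 40000 nM to 300000 nM. The step expected is a step that the limit leaves unreadable from compound 1 to compound 4.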

Compound 4, half-maximal inhibitory concentration: > 63000 nM
Compound 4: a limit, no number; the forecaster's own chance of this, stated with the estimate: 85%; the middle value is on the limit's open side.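

In this assay compound 4 gives a limit, as compound 1 does, so no step can be read between these two compounds: the limit of > 63000 nM in this assay, at which 4 of the 4 values shown sit.

The compounds shown leave open how strongly any of them inhibits, and whether thiophen-2-yl and 3-fluorophenyl on the sulfonyl sulfur differ at all.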